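The source may report more compounds than this note shows. Statements on the series, on what has been measured and on what is new or still open speak of the compounds shown alone.

Compound 1 `CCOC[C@H]1O[C@@H](n2c(Cl)nc3cc(Cl)c(Cl)cc32)[C@H](OC(C)=O)[C@@H]1OC(C)=O`: 60000 nM
Compound 2 `CC(=O)OC1C(CF)OC(n2c(Cl)nc3cc(Cl)c(Cl)cc32)C1OC(C)=O`: 100000 nM

In a functional assay on KB cells (Homo sapiens) for inhibition (a lower number here means a stronger inhibitor, a higher number a weaker inhibitor), compound 2 gives 100000 nM and compound 1 gives 60000 nM. These two values lie within the usual scatter of each other, so they cannot be ranked, and both are large numbers on this scale. Compound 3 `CC(=O)OC1C(CBr)OC(n2c(Cl)nc3cc(Cl)c(Cl)cc32)C1OC(C)=O` is made from compound 2 by one exchange: bromo in place of fluoro on a saturated chain carbon bound to a saturated ring carbon. For the measured compounds named here, no measured pair shows this change, so no step beyond the scatter is expected in this assay, in either direction. Compound 3 is estimated at 70000 nM, with an expected range of 25000 nM to 200000 nM.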

Compound 3, half-maximal inhibitory concentration: 60000 nM
The estimate for compound 3 lay 1.2-fold (0.07 log units) above the measured number, and the stated range covers the measured number.
By their numbers in this assay, from the lowest: compounds 1, 3 and 2 (each within the scatter of the next).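

In this assay, for the compounds shown here, compound 2 and compound 3 give the one direct reading of this position, a saturated chain carbon bound to a saturated ring carbon: bromo in place of fluoro gives a 1.7-fold lower number from compound 2 to compound 3 (0.22 log units; within the scatter). The two halogens therefore cannot be told apart here, and the numbers stay large on this scale. No measured evidence bears on this result. Open, from the compounds shown here alone, is whether a hydroxymethyl, an aminomethyl or a longer chain in place of fluoromethyl would give a step beyond the scatter.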